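Adding an isobutyl group to compound 2

The source may hold more compounds than are shown below. What is called first, only, known or untested is meant among the compounds shown, and "the series" means these compounds.

Compound 2 `CCCCCC(O)C#CC#CCO` has no exact number in a toxicity assay on Hepa-1c1c7 cells (Mus musculus) for inhibition; a lower number here means a stronger inhibitor, a higher number a weaker inhibitor. Compound 2 reaches only a limit, > 50000 nM. Compound 3 `CCCCC[C@H](O)C#CC#CCO`, the same structure with its stereocentre drawn as S, also reaches only a limit, > 100000 nM. The comparison a step that the two limits leave unreadable from compound 2 to compound 3 therefore offers no usable size.

Compound 1 `CCCCCC(O)C#CC#CC(O)CCC` does give a number, 19000 nM, and it carries propyl where compound 2 has hydrogen. For the measured compounds named here, that swap is the only readable guide: an at least 2.6-fold higher number from compound 1 to compound 2 (0.42 log units; beyond the scatter). Compound 4 `CCCCCC(O)C#CC#CC(O)CC(C)C` brings a closely related change to compound 2: isobutyl in place of hydrogen on a saturated chain carbon bound to an oxygen on a saturated carbon and a triple-bonded carbon. Both propyl and isobutyl are carbon chains at this same place, so compound 4 is expected to resemble compound 1, whose value is 19000 nM.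

In this assay, the expected change is an at least 2.9-fold lower number from compound 2 to compound 4 (0.46 log units; beyond the scatter), a move towards a lower number and a stronger inhibitor. For compound 4 the estimate is 17000 nM, with an expected range from 7000 nM to 40000 nM.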

Compound 4, half-maximal inhibitory concentration: 41000 nM
Beside the measured number, compound 4's estimate is 2.4-fold (0.38 log units) below it; measured number above the stated range.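

In this assay isobutyl in place of hydrogen gives an at least 1.2-fold lower number from compound 2 to compound 4 (0.08 log units; that floor lies within the scatter) and so does not show on its own that this carbon chain lowers the number. Compound 2 has only a limit (> 50000 nM) and that is why the true size of this step cannot be given: the limit of > 50000 nM in this assay, at which 1 of the 4 values shown sits. The clearer finding is that methyl in place of hydrogen on a saturated chain carbon bound to two saturated chain carbons gives a 2.2-fold higher number from compound 1 to compound 4 (0.33 log units; beyond the scatter) and thus a weaker inhibitor, so the branched isobutyl and the unbranched propyl are not interchangeable at this position.

The compounds shown leave open whether a longer unbranched chain, an amine or a carboxylic acid at this place would give a lower number than propyl. As far as these compounds go, the step from compound 2 to compound 3 cannot be read, so the effect of the S configuration also stays open.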